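The source may report more compounds than this note shows. Statements on the series, on what has been measured and on what is new or still open speak of the compounds shown alone.

Compound 1 `CC(C)(C)NC(=O)c1c(N)sc(-c2ccc(Cl)cc2)c1-c1ccc(Cl)cc1` gives 8850 nM in a functional assay on A549 cells (Homo sapiens) for inhibition, read by sulforhodamine B assay, with a stated time of 72 h; a lower number here means a stronger inhibitor, a higher number a weaker inhibitor.
Compound 2 `Nc1sc(-c2ccc(Cl)cc2)c(-c2ccc(Cl)cc2)c1C(=O)NC1CCCCC1` gives 2410 nM in this assay.
Compound 3 `Nc1sc(-c2ccc(Cl)cc2)c(-c2ccc(Cl)cc2)c1C(=O)NC1CC1` gives 1950 nM in this assay.

Compound 3 holds the lowest of the three numbers, but its gap to compound 2 is within the scatter a 1.2-fold lower number from compound 2 to compound 3 (0.09 log units; within the scatter), so the two cannot be ordered; only compound 1 stands clearly apart a 4.5-fold lower number from compound 1 to compound 3 (0.66 log units; beyond the scatter).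

Compound 4 `CC(C)CNC(=O)c1c(N)sc(-c2ccc(Cl)cc2)c1-c1ccc(Cl)cc1` differs from compound 3 in one place: isobutyl in place of cyclopropyl on an amide-type nitrogen. For the measured compounds named here, two measured steps bear on this. Replacing tert-butyl with a ring on the amide-type nitrogen lowered the number in both cases, a 3.7-fold lower number from compound 1 to compound 2 (0.56 log units; beyond the scatter) and a 4.5-fold lower number from compound 1 to compound 3 (0.66 log units; beyond the scatter), whereas exchanging one ring for another made no difference beyond the scatter a 1.2-fold lower number from compound 2 to compound 3 (0.09 log units; within the scatter). Isobutyl, like tert-butyl, is a branched chain without a ring, so a move back toward compound 1 is expected, though a smaller one, since only tert-butyl itself is known to be weak. The step to compound 4 in this assay is therefore expected to be a modest rise, a 1.8-fold higher number from compound 3 to compound 4 (0.25 log units; within the scatter). Compound 4 is estimated at 3500 nM, within 1500 nM to 8000 nM.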

Compound 4, half-maximal inhibitory concentration: 21000 nM
Compound 4: the middle estimate sits 6.0-fold (0.78 log units) below what was measured; measured number outside the range, above it.
By their numbers in this assay, from the lowest: compounds 3 and 2 (each within the scatter of the next); then compound 1; then compound 4.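

In this assay, isobutyl on the amide-type nitrogen does not fall between the ring groups and tert-butyl, but lands past tert-butyl (a 2.4-fold higher number from compound 1 to compound 4 (0.38 log units; beyond the scatter)). The gaps to the ring-bearing amides are wider still (an 11-fold higher number from compound 3 to compound 4 (1.03 log units; beyond the scatter); an 8.7-fold higher number from compound 2 to compound 4 (0.94 log units; beyond the scatter)), so among these four compounds the two ring groups, cyclopropyl and cyclohexyl, stand apart from the two ringless chains, and this position tolerates a far wider spread than the first three compounds showed. Nothing measured here explains why isobutyl and tert-butyl differ or why the ringless chains trail the ring groups.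

From the compounds shown here alone, it remains open whether an unbranched chain such as n-butyl would follow isobutyl or whether a cyclobutyl or cyclopentyl ring would match compound 3. Equally open, going by these compounds, is how a benzyl group or a chain ending in an amine would behave at this nitrogen.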